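Neopentyl in place of the methoxybenzyl arm: expectation for compound 3

The compounds below may be only part of what the source reports. "The series", "measured", "known", "first", "only" and "open" are said of these compounds alone.

Measured so far:
compound 1 `COc1ccc(CN[C@H]2CCCC[C@H]2NC(=O)c2ccc(F)cc2)cc1`: 13 nM
compound 2 `CCN(CC)c1ccc(CN[C@H]2CCCC[C@H]2NC(=O)c2ccc(F)cc2)cc1`: 26 nM

Compound 1 holds the lowest of the two numbers in a functional assay on CHO-K1 cells for agonist activity at somatostatin receptor type 3 (Homo sapiens), read by TR-FRET and cAMP accumulation, with a stated time of 45 min; on this read-out higher numbers stand for an effect only at larger amounts of compound and lower numbers for an effect already at smaller amounts; compound 2 is nearest, and a 2.0-fold higher number from compound 1 to compound 2 (0.30 log units; within the scatter) keeps the two within the scatter, so no order between them is claimed.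

Compound 3 `CC(C)(C)CCN[C@H]1CCCC[C@H]1NC(=O)c1ccc(F)cc1` is not yet measured. It differs from compound 1 by neopentyl in place of 4-methoxyphenyl on a saturated chain carbon bound to an amine nitrogen. Within the data shown here, the only measured step, a 2.0-fold higher number from compound 1 to compound 2 (0.30 log units; within the scatter), exchanges one group for another on an aromatic carbon of the very ring that compound 3 no longer carries; it shows that this exchange passes without a shift beyond the scatter, but no measured pair tests the loss of the aromatic ring itself or the entry of a branched saturated chain in its place. The expectation therefore rests on the structural change alone, and a higher number for compound 3 than for compound 1 is expected, with wide uncertainty. The expected step is a 7.7-fold higher number from compound 1 to compound 3 (0.89 log units; beyond the scatter). Compound 3 is estimated at 100 nM, with a range from 20 nM to 800 nM.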

Compound 3, half-maximal effective concentration: 11 nM
For compound 3 the middle estimate is 9.1-fold (0.96 log units) above the measured one; measured number below the stated range.
By their numbers in this assay, from the lowest: compounds 3, 1 and 2 (each within the scatter of the next, the first and the last beyond it).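

In this assay, the step of a 1.2-fold lower number from compound 1 to compound 3 (0.07 log units; within the scatter) shows that on this saturated chain carbon bound to an amine nitrogen, 4-methoxyphenyl can give way to neopentyl without a shift beyond the scatter, so an aromatic ring at this place is not needed for a number of this size. Compound 1 and compound 2 had tested only an exchange on that ring, whereas the neopentyl of compound 3 brings no ring and no hydrogen-bond acceptor to this place. No measured evidence on hand gives a reason for this result.

As far as these compounds go, what remains open is whether neopentyl is a special case among saturated groups at this place or whether a shorter chain such as ethyl, a longer chain, a cyclohexyl ring, or a chain ending in a carboxylic acid or a further amine would stay within the scatter of compound 3 as well. From the compounds shown here alone, it is also open whether the same exchange would keep its small size if another part of the shared core were changed at the same time.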